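The source may hold more compounds than are shown below. What is called first, only, known or untested is meant among the compounds shown, and "the series" means these compounds.

The measured compounds:
compound 1, `COc1cc(Oc2cccc(Nc3ccccc3)c2)cc(OC)c1CNCCNC(C)=O`: 5090 nM
compound 2, `COc1cc(Oc2cccc(Nc3ccccc3)c2)cc(OC)c1CNCc1ccc(F)cc1`: 3640 nM

Both compounds share a core and differ only in the group carried on the chain that leaves the core. In a functional assay on HCT-15 cells (Homo sapiens) for inhibition, read by MTT assay, with a stated time of 72 h (on this read-out lower numbers stand for stronger inhibition and higher numbers for weaker inhibition), compound 1 gives 5090 nM, and compound 2 gives 3640 nM; the two values lie within the scatter of each other, as the step of a 1.4-fold lower number from compound 1 to compound 2 (0.15 log units; within the scatter) shows, so neither stands apart from the other.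

Compound 3, `COc1cc(Oc2cccc(Nc3ccccc3)c2)cc(OC)c1CN(C)C`, has not yet been measured. Compared with compound 1 the change is dimethylamino in place of (2-acetamidoethyl)amino on a saturated chain carbon bound to an aromatic carbon. Among the compounds with values here, the one measured step that touches this part of the molecule, a 1.4-fold lower number from compound 1 to compound 2 (0.15 log units; within the scatter), exchanged a larger group there without moving the number beyond the scatter. On that basis no step beyond the scatter is expected for compound 3 either, as a 1.1-fold lower number from compound 1 to compound 3 (0.05 log units; within the scatter) expresses. Compound 3 is therefore expected to give about 4500 nM, within a range of 1500 nM to 13000 nM.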

Compound 3, half-maximal inhibitory concentration: 15600 nM
Compound 3: the middle estimate sits 3.5-fold (0.54 log units) below what was measured; measured number above the stated range.
By their numbers in this assay, from the lowest: compounds 2 and 1 (each within the scatter of the next); then compound 3.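

The step of a 3.1-fold higher number from compound 1 to compound 3 (0.49 log units; beyond the scatter) in this assay replaces (2-acetamidoethyl)amino with dimethylamino, and the step of a 4.3-fold higher number from compound 2 to compound 3 (0.63 log units; beyond the scatter) replaces (4-fluorobenzyl)amino with dimethylamino. The group on this saturated chain carbon bound to an aromatic carbon can therefore move the number beyond the scatter, which compound 1 and compound 2 alone could not show, since their two quite different groups lie within the scatter of each other. What sets dimethylamino apart from the other two groups cannot be told from these compounds, as no measurement here speaks to a cause.

Going by these compounds, it remains open where between these groups the change sets in, for example with methylamino or a plain amino group at this place. Also open, on these data alone, is how a ring amine such as morpholine, or a chain ending in a carboxylic acid, would compare.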